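The source may hold more compounds than are shown below. What is called first, only, known or untested is meant among the compounds shown, and "the series" means these compounds.

Measured so far:
Compound 1, `O=C(O)c1ccccc1-c1ccc(CCc2ncc(CC3CCOCC3)[nH]2)cc1`: in an in vitro functional assay on cells for agonist activity at Bombesin receptor subtype-3 (Homo sapiens), read by luminescence and calcium flux (on this read-out lower numbers stand for an effect already at smaller amounts and higher numbers for an effect only at larger amounts of compound), compound 1 gives 338 nM.
Compound 2, `O=C(O)c1ccccc1-c1ccc(CCc2ncc(Cc3ccccc3Cl)[nH]2)cc1`: in this assay compound 2 gives 292 nM.
Compound 3, `CC(C)(C)Cc1cnc(CCc2ccc(-c3ccccc3C(=O)O)cc2)[nH]1`: in this assay compound 3 gives 106 nM.

Compound 3 stands lowest of the three numbers; its nearest neighbour is compound 2, which lies beyond the scatter from it, and compound 1 lies further still. Compound 4, `CC(C)CCc1cnc(CCc2ccc(-c3ccccc3C(=O)O)cc2)[nH]1`, is not yet measured; it differs from compound 3 by isobutyl in place of tert-butyl on a saturated chain carbon bound to an aromatic carbon.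

Among the measured compounds shown here, no measured step makes this exact change, but all three steps sit at the same place. The steps of a 3.2-fold lower number from compound 1 to compound 3 (0.50 log units; beyond the scatter) and a 2.8-fold lower number from compound 2 to compound 3 (0.44 log units; beyond the scatter) both end at the tert-butyl group of compound 3 and both lowered the number modestly, while a 1.2-fold lower number from compound 1 to compound 2 (0.06 log units; within the scatter) stayed within the scatter. Whether a branched chain with the same atoms, joined differently, keeps the number of compound 3 cannot be read from these steps alone. Compound 4 is therefore expected to stay close to compound 3, with the step of a 1.5-fold higher number from compound 3 to compound 4 (0.18 log units; within the scatter) estimated at most a small increase in this assay. Compound 4 is estimated at 160 nM, in a range from 60 nM to 420 nM.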

Compound 4, half-maximal effective concentration: 119 nM
Compound 4: middle estimate off by 1.3-fold (0.13 log units), on the high side; low and high end bracket the measured number.
By their numbers in this assay, from the lowest: compounds 3 and 4 (each within the scatter of the next); then compounds 2 and 1 (each within the scatter of the next).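

Swapping tert-butyl for isobutyl, the same atoms joined differently, leaves the number within the scatter in this assay (a 1.1-fold higher number from compound 3 to compound 4 (0.05 log units; within the scatter)), so on a saturated chain carbon bound to an aromatic carbon these data do not separate the two branched chains. Isobutyl also shows the modest distance from both ring-bearing groups that tert-butyl showed, for 2-chlorophenyl (a 2.5-fold lower number from compound 2 to compound 4 (0.39 log units; beyond the scatter)) and for oxan-4-yl (a 2.8-fold lower number from compound 1 to compound 4 (0.45 log units; beyond the scatter)). Among these four compounds, then, both branched chains give lower numbers than both ring-bearing groups, and no compound shown goes against this.

The compounds shown leave open what a longer straight chain, a shorter ethyl group or an amine on the chain would give at this position. No independent evidence is available that bears on this result.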